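Notes on a second chloro on the shared core

This account rests on a few compounds, and the source may have more. Where it says the series, first, only, none or still open, it means among the compounds named here.

Measured so far:
Compound 1 `ClCc1cccc(Cn2cnc3ncnc(Cl)c32)c1`: in a functional assay on NCI-H23 cells (Homo sapiens) for cytotoxicity, read by sulforhodamine B assay, with a stated time of 48 h (a lower number here means a stronger inhibitor of growth, a higher number a weaker inhibitor of growth), compound 1 gives 3380 nM.
Compound 2 `ClCc1cccc(Cn2cnc3c(Cl)ncnc32)c1`: in this assay compound 2 gives 4070 nM.

Compound 1 and compound 2 share the same benzyl substituent and differ only in where the single chloro sits on the core. Their two numbers in this assay lie within the usual scatter of each other, so nothing separates them; compound 2 stands with compound 1 at the same level.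

Compound 3 `ClCc1cccc(Cn2cnc3c(Cl)nc(Cl)nc32)c1` keeps the arrangement of compound 2 and adds a second chloro: chloro in place of hydrogen on an aromatic carbon. The new group goes on the aromatic carbon between two ring nitrogen atoms, meta to the chloro group already present.

Among the measured compounds shown here, no measured pair shows what a second chloro on the core does, so there is no step to lean on. Given that moving the single chloro between compound 1 and compound 2 left the number within the scatter, no step beyond the scatter is expected in this assay for adding one more; the expected step is a 1.3-fold lower number from compound 2 to compound 3 (0.10 log units; within the scatter). Compound 3 is therefore estimated at 3200 nM, with a range from 1000 nM to 10000 nM.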

Compound 3, concentration for total growth inhibition: 5120 nM
Compound 3: the middle estimate sits 1.6-fold (0.20 log units) below what was measured, within the range that was stated.
By their numbers in this assay, from the lowest: compounds 1, 2 and 3 (each within the scatter of the next).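

Chloro in place of hydrogen on the aromatic carbon between two ring nitrogen atoms gives a 1.3-fold higher number from compound 2 to compound 3 (0.10 log units; within the scatter) in this assay, so a second chloro on this position leaves compound 3 at the same level as compound 2. Among the compounds shown here, compound 1 and compound 2 spoke only to where a single chloro sits on the shared core, whereas this pair is the first to differ in the number of chloro groups on it, and the added chloro brings no step beyond the scatter. No measurement on these compounds bears on why the number holds level across this change.

Going by these compounds, whether this carbon tolerates only chloro or any other group remains open, since an amine, a methoxy group or a longer chain at the same place would each have to be compared directly with compound 2 before the position could be called insensitive to substitution. Also open, on these data alone, is how much of the level shared by all three compounds depends on the benzyl substituent they have in common, a question that a hydroxymethyl group in place of the chloromethyl group on compound 3 would address.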